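The source may report more compounds than this note shows. Statements on the series, on what has been measured and on what is new or still open speak of the compounds shown alone.

Of the compounds shown here, two of a shared core have been tested in a functional assay on HL-60 cells (Homo sapiens) for cytotoxicity; a higher number here means a weaker inhibitor, a lower number a stronger inhibitor. Compound 1 `CC1(C)CCC(C)(C)c2cc(/C=C/c3ccc(N)cc3)ccc21` carries an amino group on its outer ring; in this assay compound 1 gives 18000 nM. Compound 2 `COc1ccc(/C=C/c2ccc3c(c2)C(C)(C)CCC3(C)C)cc1N` carries both an amino group and a methoxy group on that ring; in this assay compound 2 gives 61000 nM, the highest of the two numbers and therefore the weaker inhibitor of the two, since the gap between them lies beyond the usual scatter.

Compound 3 `COc1ccc(/C=C/c2ccc3c(c2)C(C)(C)CCC3(C)C)cc1` is not yet measured. It differs from compound 2 in one place: hydrogen in place of amino on an aromatic carbon, on an aromatic carbon of a six-membered aromatic ring of carbon only, ortho to a methoxy group and meta to a large group. Among the measured compounds shown here, no pair of measured compounds shows what this single change does on its own, so the step can only be estimated. Because compound 2 sits at 61000 nM and compound 1 at 18000 nM, the number for compound 3 is expected to stay in the same broad region. The expected step is a 1.5-fold lower number from compound 2 to compound 3 (0.18 log units; within the scatter). For compound 3 the estimate is 40000 nM, with a range from 15000 nM to 110000 nM.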

Compound 3, half-maximal inhibitory concentration: 50000 nM
Estimate against measurement, compound 3: 1.3-fold (0.10 log units) below; low and high end bracket the measured number.
By their numbers in this assay, from the lowest: compound 1; then compounds 3 and 2 (each within the scatter of the next).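

In this assay, among the compounds shown here, the amino group ortho to a methoxy group and meta to a large group can be judged on its own for the first time: hydrogen in place of amino on this aromatic carbon gives a 1.2-fold lower number from compound 2 to compound 3 (0.09 log units; within the scatter), so the two compounds cannot be told apart here. The second comparison concerns a different change, methoxy in place of amino on an aromatic carbon, and gives a 2.8-fold higher number from compound 1 to compound 3 (0.44 log units; beyond the scatter), which makes compound 3 the weaker inhibitor of that pair, though only modestly. Within these two pairs, then, removing the amino group beside the methoxy group leaves no readable mark on the number, while exchanging amino for methoxy does. Nothing available explains why either step has the size it has.

As far as these compounds go, it remains open whether any other group at the place ortho to the methoxy group, such as a hydroxyl group, a fluorine atom or a carboxylic acid, would move the number beyond the scatter. It is also unknown whether a longer chain in place of the methoxy group would give a stronger inhibitor than the compounds shown.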